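The source may hold more compounds than are shown below. What is called first, only, known or untested is meant among the compounds shown, and "the series" means these compounds.

Measured compounds:
compound 1 `Nc1cc(N)c2nc(-c3ccccc3)c(NCc3ccc(Cl)c(Cl)c3)nc2c1` — 12300 nM
compound 2 `CCOC(=O)[C@H](CCC(=O)O)NC(=O)c1ccc(Sc2nc3cc(N)cc(N)c3nc2-c2ccccc2)cc1` — 5750 nM
compound 3 `CCOC(=O)[C@H](CCC(=O)O)NC(=O)c1ccc(CNc2nc3cc(N)cc(N)c3nc2-c2ccccc2)cc1` — < 100000 nM

Of the compounds shown here, three sharing one core have been tested in a functional assay on MCF7 cells (Homo sapiens) for inhibition, read by sulforhodamine B assay, with a stated time of 48 h; a higher number here means a weaker inhibitor of growth, a lower number a stronger inhibitor of growth. Compound 1 gives 12300 nM, the higher of the two numbers recorded. Compound 2 gives 5750 nM, a lower number, and the gap between compound 1 and compound 2 lies beyond the usual scatter. For compound 3 the result is a limit rather than a number, < 100000 nM, (the limit of < 100000 nM in this assay, at which 1 of the 3 values shown sits); nothing more can be read from it.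

Compound 4 `Nc1cc(N)c2nc(-c3ccccc3)c(NCc3ccc(F)cc3)nc2c1` has not yet been measured in this assay. It differs from compound 1 in one place: 4-fluorophenyl in place of 3,4-dichlorophenyl on a saturated chain carbon bound to a nitrogen on an aromatic ring. Going by the values given here, no measured pair here shows the same change, so the expectation for compound 4 rests on compound 1 alone. The account expects a modest move toward a weaker inhibitor, a step from compound 1 to compound 4 of a 1.6-fold higher number from compound 1 to compound 4 (0.21 log units; within the scatter), which may not exceed the scatter. Compound 4 is therefore estimated at 20000 nM, with a range from 7000 nM to 60000 nM.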

Compound 4, concentration for 50% growth inhibition: 3020 nM
Compound 4: middle estimate off by 6.6-fold (0.82 log units), on the high side; the measured number lies below the stated range.
By their numbers in this assay, from the lowest: compounds 4 and 2 (each within the scatter of the next); then compound 1.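

The phenyl ring on a saturated chain carbon bound to a nitrogen on an aromatic ring can now be seen to matter in this assay: replacing 3,4-dichlorophenyl with 4-fluorophenyl gives a 4.1-fold lower number from compound 1 to compound 4 (0.61 log units; beyond the scatter). The two chlorine atoms are therefore not required at this place for growth inhibition in these cells, and a ring bearing a single fluorine gives the lower number, although this rests on one pair of compounds. Nothing given here accounts for the step.

Going by these compounds, whether the change comes from losing the chlorine atoms or from gaining the fluorine stays open, and an unsubstituted benzyl or a 4-chlorobenzyl group would separate the two. On these data alone, it is also open whether a carboxylic acid or an amine on this ring, or a longer chain to the nitrogen, would keep the lower number.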